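Propyl to isopropyl on a side-chain amine

The compounds below may be only part of what the source reports. "The series", "measured", "known", "first", "only" and "open" are said of these compounds alone.

Among the compounds with values here, only two compounds with this core have been measured so far. In a functional assay on MCF7 cells (Homo sapiens) for antiproliferative activity (on this read-out lower numbers stand for stronger inhibition and higher numbers for weaker inhibition), compound 1 `CC(C)=CCc1cc(C(=O)Nc2cc3ccc(OCC4CCN(C)C4)c(C)c3oc2=O)ccc1O` gives 1550 nM and compound 2 `CCCNCCCOc1ccc2cc(NC(=O)c3ccc(O)c(CC=C(C)C)c3)c(=O)oc2c1C` gives 980 nM. Within the data shown here, compound 2 therefore stands level with the only other number available: the single measured step, a 1.6-fold lower number from compound 1 to compound 2 (0.20 log units; within the scatter), puts the two within the usual scatter of each other. Compound 3 `CC(C)=CCc1cc(C(=O)Nc2cc3ccc(OCCCNC(C)C)c(C)c3oc2=O)ccc1O` has the same atoms as compound 2, joined differently: isopropyl in place of propyl on an amine nitrogen. Among the measured compounds shown here, no measured pair tests this swap directly. The nearest evidence is that measured step, which replaced 1-methylpyrrolidin-3-yl with 2-(propylamino)ethyl and stayed within the scatter. A step beyond the scatter is therefore not expected here. The expected change is a 1.1-fold higher number from compound 2 to compound 3 (0.05 log units; within the scatter). Compound 3 is estimated at 1100 nM, with an expected range of 450 nM to 2700 nM.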

Compound 3, half-maximal inhibitory concentration: 740 nM
Estimate against measurement, compound 3: 1.5-fold (0.17 log units) above; the measured number falls inside the stated range.
By their numbers in this assay, from the lowest: compounds 3, 2 and 1 (each within the scatter of the next, the first and the last beyond it).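

Swapping propyl for isopropyl on the amine nitrogen, which rearranges the same atoms, gives a 1.3-fold lower number from compound 2 to compound 3 (0.12 log units; within the scatter) in this assay, so on this read-out the two groups cannot be told apart at this position. Within the data shown here, the replacement of 1-methylpyrrolidin-3-yl with 2-(isopropylamino)ethyl on the saturated chain carbon bound to an oxygen on an aromatic ring gives a 2.1-fold lower number from compound 1 to compound 3 (0.32 log units; beyond the scatter), the first modest step in this set that lies beyond the scatter, while compound 2 remains within the scatter of both other compounds. Nothing available here accounts for these numbers.

As far as these compounds go, whether a tert-butyl or a cyclopropyl on the same amine nitrogen would give a step beyond the scatter remains open. So does the effect of a free primary amine, which would carry only hydrogens in place of the propyl or isopropyl.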